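Losing the 3-methylbut-2-en-1-yl group from compound 1

The source may report more compounds than this note shows. Statements on the series, on what has been measured and on what is new or still open speak of the compounds shown alone.

In a functional assay on A549 cells (Homo sapiens) for inhibition, read by MTT assay, with a stated time of 72 h (on this read-out lower numbers stand for stronger inhibition and higher numbers for weaker inhibition), compound 1 (`COc1ccc(/C=C/C(=O)c2c(OC)cc(O)c(CC=C(C)C)c2O)cc1`) gives 38000 nM at the high end of the series. Compound 3 (`COc1cc(O)c(CC=C(C)C)c(O)c1C(=O)/C=C/c1ccc([N+](=O)[O-])cc1`) gives 31200 nM within the scatter of compound 1, while compound 2 (`COc1cc(O)c(CC=C(C)C)c(O)c1C(=O)/C=C/c1ccc(Cl)cc1`) gives 11800 nM as the lowest number. Compound 4 (`COc1ccc(/C=C/C(=O)c2c(O)cc(O)cc2OC)cc1`) differs from compound 1 by hydrogen in place of 3-methylbut-2-en-1-yl on an aromatic carbon with hydrogen in place of 3-methylbut-2-en-1-yl on an aromatic carbon. Within the data shown here, no measured step touches that place. The nearest guides are a 3.2-fold lower number from compound 1 to compound 2 (0.51 log units; beyond the scatter) for chloro in place of methoxy and a 1.2-fold lower number from compound 1 to compound 3 (0.09 log units; within the scatter) for nitro in place of methoxy, so only a small shift toward a higher number is expected. The estimated step is a 1.3-fold higher number from compound 1 to compound 4 (0.12 log units; within the scatter) in this assay with no change beyond the scatter expected. Compound 4 is estimated at 50000 nM with an expected range from 20000 nM to 120000 nM on this read-out.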

Compound 4, half-maximal inhibitory concentration: > 50000 nM
Compound 4 gave a limit, no number; the forecaster's own chance of this, stated with the estimate: 20%; the middle value lies on the limit itself.
By their numbers in this assay, from the lowest: compound 2; then compounds 3 and 1 (each within the scatter of the next). At a limit, above all of these: compound 4.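

Compounds 2 and 3 changed only the methoxy group, while compound 4 is the only one here that alters the place carrying the chain. In this assay, compound 4 gives a limit, not a number: the limit of > 50000 nM in this assay, at which 1 of the 4 values shown sits. Hydrogen in place of 3-methylbut-2-en-1-yl gives an at least 1.3-fold higher number from compound 1 to compound 4 (0.11 log units; that floor lies within the scatter), so losing the chain brings no lower number, but how much the chain contributes cannot be read from this floor.

From the compounds shown here alone, it remains open how a methyl group, a longer chain or an amine on this carbon would read. Also open, going by these compounds, is whether chloro in place of methoxy would lower the number without the chain.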